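The source may hold more compounds than are shown below. What is called first, only, known or untested is meant among the compounds shown, and "the series" means these compounds.

Three compounds sharing one core were tested in a functional assay on the whole organism with Rattus norvegicus as the target; on this read-out lower numbers stand for an effect already at smaller amounts and higher numbers for an effect only at larger amounts of compound. Compound 1 `COC(=O)Cn1c(=N)sc2cc(OC(F)(F)F)ccc21` gives > 10 mg/kg, which is a limit of the assay rather than a number. Compound 2 `N=c1sc2cc(OC(F)(F)F)ccc2n1CC(=O)O` gives > 10 mg/kg, also a limit. Compound 3 `CCSCCn1/c(=N/OC)sc2cc(OC(F)(F)F)ccc21` gives > 10 mg/kg, again a limit. Compound 1 becomes compound 2 through (hydrogen in place of methyl on an oxygen next to a carbonyl group), and that change gave a step that the two limits leave unreadable from compound 1 to compound 2. How the core of compound 3 differs from that of compound 1 is not broken down here. Compound 4 `CCSCCn1/c(=N/O)sc2cc(OC(F)(F)F)ccc21` is not yet measured; it differs from compound 3 by hydrogen in place of methyl on an oxygen. This is the same kind of change as the earlier one, not the same: there the oxygen sits next to a carbonyl group, with a carbonyl carbon as its other neighbour, while here the oxygen's other neighbour is a double-bonded nitrogen. Since all three values sit at the limit of > 10 mg/kg in this assay, at which 3 of the 3 values shown sit, the earlier step has no readable size. The step from the shared limit is expected to be a step that the limit leaves unreadable from compound 3 to compound 4. Compound 4 is therefore estimated at 15 mg/kg.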

Compound 4, dose for half-maximal effect: > 10 mg/kg
Compound 4 was reported as a limit (the forecaster's own chance of this, stated with the estimate: 70%); the middle value lies beyond the limit too.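

No step can be read between compound 3 and compound 4, since both values are limits of the assay: the limit of > 10 mg/kg in this assay, at which 4 of the 4 values shown sit. The compounds shown leave open how far any of these changes shifts the dose in this assay on this core.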